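The compounds below may be only part of what the source reports. "The series", "measured", "known", "first", "only" and "open" are said of these compounds alone.

Notes on the series. In a functional assay on HT-29 cells (Homo sapiens) for cytotoxicity, read by MTT assay, with a stated time of 24 h, tested at 32 ug/mL (a higher number here means a stronger effect of the compound at the concentration tested, a lower number a weaker effect), compound 1 `Cn1c(-c2ccc(NC(=O)CCl)cc2)nc(-c2ccccc2)c1-c1ccccc1` gives 53.2%, compound 2 `Cn1c(-c2ccc(NC(=O)CSC3=NCCS3)cc2)nc(-c2ccccc2)c1-c1ccccc1` gives 59.4% and compound 3 `Cn1ccnc1SCC(=O)Nc1ccc(-c2nc(-c3ccccc3)c(-c3ccccc3)n2C)cc1` gives 41.1%. Compound 3 stands lowest of the three: a number 12.1 percentage points lower from compound 1 to compound 3 (beyond the scatter) and a number 18.3 percentage points lower from compound 2 to compound 3 (beyond the scatter), while a number 6.2 percentage points higher from compound 1 to compound 2 (within the scatter). All three steps alter the same place, the saturated chain carbon bound to the carbonyl carbon, and none exceeds a modest size. Compound 4 `CN1CCN(CC(=O)Nc2ccc(-c3nc(-c4ccccc4)c(-c4ccccc4)n3C)cc2)CC1` carries 4-methylpiperazin-1-yl in place of (1-methyl-1H-imidazol-2-yl)sulfanyl on a saturated chain carbon bound to a carbonyl carbon. Among the compounds with values here, no measured compound carries this group, so the only steps bearing on it are the three above, which point to a small movement at this place. Compound 4 is expected to fall between compound 3 and compound 1. The expected step is a number 6.9 percentage points higher from compound 3 to compound 4 (within the scatter). Compound 4 is estimated at 48%, with a range from 33% to 63%.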

Compound 4, a percentage reported as activity, at one concentration (the size of the read-out at that concentration, not a potency): 49.1%
The estimate for compound 4 lay 1.1 percentage points below the measured number, and the stated range covers the measured number.
By their numbers in this assay, from the lowest: compounds 3, 4, 1 and 2 (each within the scatter of the next, the first and the last beyond it).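

Unlike the chloro and sulfanyl groups at this saturated chain carbon bound to a carbonyl carbon, 4-methylpiperazin-1-yl shows that the place needs neither for a read-out of this size, with a number 4.1 percentage points lower from compound 1 to compound 4 (within the scatter) and a number 8 percentage points higher from compound 3 to compound 4 (within the scatter) in the series. Only a number 10.3 percentage points lower from compound 2 to compound 4 (beyond the scatter) goes beyond the scatter, so compound 2 now stands clear of both compound 3 and compound 4. Nothing at hand explains these differences.

Still open, from the compounds shown here alone, is whether morpholin-4-yl or piperazin-1-yl without the methyl would read like 4-methylpiperazin-1-yl. A longer chain carrying the same ring also remains untested in the compounds shown here.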